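The source may report more compounds than this note shows. Statements on the series, on what has been measured and on what is new or still open speak of the compounds shown alone.

Measured in a functional assay on A549 cells (Homo sapiens) for antiproliferative activity, read by MTT assay, with a stated time of 48 h; a lower number here means a stronger inhibitor, a higher number a weaker inhibitor:
compound 1, `CC=C(/C=C/c1ccc(OC)c(N)c1)c1cc(OC)c(OC)c(OC)c1`, gives 247 nM
compound 2, `CCC=C(/C=C/c1ccc(OC)c(N)c1)c1cc(OC)c(OC)c(OC)c1`, gives 398 nM
compound 3, `CCC=C(/C(C)=C/c1ccc(OC)c(O)c1)c1cc(OC)c(OC)c(OC)c1`, gives 2020 nM

Compounds 1 and 2 share one core and differ in a single spot, (methyl in place of hydrogen on a saturated chain carbon bound to a double-bonded chain carbon). This change produced a 1.6-fold higher number from compound 1 to compound 2 (0.21 log units; within the scatter), so the two numbers cannot be told apart with confidence. Compound 3 carries a different core; how its core differs from that of compound 1 is not broken down here. In this assay compound 3 has the highest of the three numbers, and its gaps to compound 2 and to compound 1 both lie beyond the usual scatter.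

Compound 4, `CCCC=C(/C(C)=C/c1ccc(OC)c(O)c1)c1cc(OC)c(OC)c(OC)c1`, is not yet measured. It is derived from compound 3 by methyl in place of hydrogen on a saturated chain carbon, two bonds along the chain from a double-bonded chain carbon. Among the compounds with values here, this is the same kind of change as the one from compound 1 to compound 2, but not the same: there the new methyl sat on a saturated chain carbon bound to a double-bonded chain carbon, whereas here it sits on a saturated chain carbon, two bonds along the chain from a double-bonded chain carbon, and the surrounding core is also different.

Because the matching change gave a 1.6-fold higher number from compound 1 to compound 2 (0.21 log units; within the scatter), a similarly small step is expected here, and the step from compound 3 to compound 4 is estimated at a 1.4-fold higher number from compound 3 to compound 4 (0.14 log units; within the scatter). Compound 4 is therefore expected to give about 2800 nM in this assay, most likely between 1400 nM and 5600 nM.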

Compound 4, half-maximal inhibitory concentration: 2460 nM
Estimate against measurement, compound 4: 1.1-fold (0.06 log units) above; the measured number falls inside the stated range.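

In this assay, methyl in place of hydrogen on the core of compound 3 turns an ethyl chain into a propyl chain and gives a 1.2-fold higher number from compound 3 to compound 4 (0.09 log units; within the scatter), so the two numbers cannot be told apart with confidence. Set beside the earlier step, this suggests that the change carries over between these two cores with no visible difference in size, and on both cores the step stays small: the same change on two cores in this assay, a 1.6-fold higher number (0.21 log units; within the scatter) from compound 1 to compound 2 and a 1.2-fold higher number (0.09 log units; within the scatter) from compound 3 to compound 4, 1.3-fold (0.12 log units) apart, within the scatter of two such steps. This does not show that the added methyl has no effect at all, since a real but small shift could hide within the scatter, and two pairs of compounds, with the new methyl sitting at a different place on the chain in each pair, cannot establish a rule for other cores.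

The compounds shown leave open whether the number stays just as flat when the chain grows further, to a butyl chain for example, or when it ends in a different group such as a carboxylic acid. They also leave open which feature of the core of compound 3 goes with its higher number, as that core differs from the core of compound 1 in more than one spot.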